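The source may report more compounds than this note shows. Statements on the series, on what has been measured and on what is new or still open speak of the compounds shown alone.

The shared core carries an amide-type nitrogen bearing a pyridyl group, and the two measured compounds, compound 1 `Cc1ccc(-c2cc(C(=O)Nc3ccncc3Br)nn2-c2ccc3ccccc3n2)cc1` and compound 2 `COc1ncccc1NC(=O)c1cc(-c2ccc(C)cc2)n(-c2ccc3ccccc3n2)n1`, differ only there. In a functional assay on HCT-116 cells (Homo sapiens) for cytotoxicity, read by sulforhodamine B assay, with a stated time of 72 h (on this read-out lower numbers stand for stronger inhibition and higher numbers for weaker inhibition), compound 1 gives 15500 nM, and compound 2 gives 15700 nM. The step of a 1.0-fold higher number from compound 1 to compound 2 (0.01 log units; within the scatter) shows that an exchange of one pyridyl group for another on the amide-type nitrogen lies within the scatter. Among the compounds with values here, compound 2 thus stands at one of two numbers that sit within the scatter of each other, with compound 1 as its only neighbour. Within the data shown here, compound 3 `Cc1ccc(-c2cc(C(=O)Nc3ccnc(Cl)c3)nn2-c2ccc3ccccc3n2)cc1` again alters only this group: 2-chloropyridin-4-yl in place of 2-methoxypyridin-3-yl on an amide-type nitrogen. Among the measured compounds shown here, the one step that bears on it, the earlier pyridyl exchange on the amide-type nitrogen, was within the scatter, so no step beyond the scatter is expected in this assay for compound 3, in either direction. Compound 3 is therefore estimated at 15000 nM, within a range of 7000 nM to 35000 nM. This estimate means an expected step of a 1.0-fold lower number from compound 2 to compound 3 (0.02 log units; within the scatter).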

Compound 3, half-maximal inhibitory concentration: 1100 nM
Beside the measured number, compound 3's estimate is 14-fold (1.13 log units) above it; the whole stated range lies above it.
By their numbers in this assay, from the lowest: compound 3; then compounds 1 and 2 (each within the scatter of the next).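

In this assay the group on the amide-type nitrogen proves able to move the number: 2-chloropyridin-4-yl in place of 2-methoxypyridin-3-yl gives a 14-fold lower number from compound 2 to compound 3 (1.15 log units; beyond the scatter) and 2-chloropyridin-4-yl in place of 3-bromopyridin-4-yl gives a 14-fold lower number from compound 1 to compound 3 (1.15 log units; beyond the scatter). A pyridyl exchange at this place is therefore not silent in general, and the earlier within-scatter pair was not representative of every such exchange. Compound 1 also carries a halogen on a pyridin-4-yl group yet sits with compound 2, so neither a halogen nor a pyridin-4-yl attachment alone goes with the lower number, and nothing at hand explains the step.

Going by these compounds, whether the chlorine itself is needed remains open, as an amine or a methyl group in its place would test. Also open, on these data alone, is whether the step holds on a different shared core.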